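Lengthening the thioether chain: from heptyl to undecyl

This account rests on a few compounds, and the source may have more. Where it says the series, first, only, none or still open, it means among the compounds named here.

Measured compounds:
- Compound 1, `CSC[C@H](NC(C)=O)C(=O)CCl`: 80800 nM
- Compound 2, `CCCCCCCSC[C@H](NC(C)=O)C(=O)CCl`: 2500 nM
- Compound 3, `CCCCCCCCSC[C@H](NC(C)=O)C(=O)CCl`: 4100 nM

All three share one core, a chloromethyl ketone carrying an acetylamino group and a sulfur-linked side chain, and were tested in a functional assay on MOLT-3 cells (Homo sapiens); on this read-out higher numbers stand for weaker inhibition and lower numbers for stronger inhibition. Compound 2 gives the lowest number of the three, but its separation from compound 3 is a 1.6-fold higher number from compound 2 to compound 3 (0.21 log units; within the scatter), so the two cannot be ranked against each other; only compound 1 stands clearly apart, with a 32-fold lower number from compound 1 to compound 2 (1.51 log units; beyond the scatter).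

Compound 4, `CCCCCCCCCCCSC[C@H](NC(C)=O)C(=O)CCl`, is not yet measured. It differs from compound 2 by butyl in place of hydrogen on a saturated chain carbon, seven bonds along the chain from a sulfur.

For the measured compounds named here, two measured steps bear on this. The step from a bare methyl to a heptyl chain was large, a 32-fold lower number from compound 1 to compound 2 (1.51 log units; beyond the scatter), while extending the heptyl chain by one more carbon gave a 1.6-fold higher number from compound 2 to compound 3 (0.21 log units; within the scatter), a change within the scatter. The change to compound 4 extends the chain further than compound 3 does, in the same direction as the small step. The large gain from compound 1 to compound 2 already seems spent, so no further step beyond the scatter is expected in this assay, or at most a slight rise in the number.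

Compound 4 is therefore estimated at 5000 nM, within a range of 1500 nM to 17000 nM. This estimate corresponds to an expected step of a 2.0-fold higher number from compound 2 to compound 4 (0.30 log units; within the scatter).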

Compound 4, half-maximal inhibitory concentration: 3000 nM
Compound 4: middle estimate off by 1.7-fold (0.22 log units), on the high side; measured number inside the range.
By their numbers in this assay, from the lowest: compounds 2, 4 and 3 (each within the scatter of the next); then compound 1.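

In this assay, butyl in place of hydrogen on a saturated chain carbon, seven bonds along the chain from a sulfur, turns the heptyl chain of compound 2 into the undecyl chain of compound 4, and the result is a 1.2-fold higher number from compound 2 to compound 4 (0.08 log units; within the scatter). The comparison with the octyl chain gives a 1.4-fold lower number from compound 3 to compound 4 (0.14 log units; within the scatter), so compounds 2, 3 and 4 cannot be ranked, and the lack of a readable change seen for one added carbon now also holds for a much longer addition of four carbons. No measured evidence here accounts for this insensitivity to chain length.

The compounds shown leave open how the number moves on chains shorter than heptyl, such as a propyl or pentyl chain bound to the sulfur, and whether a chain longer than undecyl, such as hexadecyl, would still fall within the scatter of compound 2. Also open, as far as these compounds go, is whether an amine or a carboxylic acid carried on the chain would change the number in this assay, this assay.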